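Inverting the ring stereocentre of compound 1

The source may report more compounds than this note shows. Statements on the series, on what has been measured and on what is new or still open speak of the compounds shown alone.

Of the compounds shown here, three have been measured so far in a functional assay on BXPC-3 cells (Homo sapiens) for inhibition, read by MTT assay, with a stated time of 7 days (a lower number here means a stronger inhibitor, a higher number a weaker inhibitor), and one remains open. Compound 1 (`CCOC(=O)[C@H]1CCN(S(=O)(=O)c2ccc(S(=O)(=O)N(CC)CC)cc2)C1`) gives 29300 nM and holds the highest number of the three, which makes it the weakest inhibitor measured to date. Compound 2 (`CCOC(=O)C1CN(S(=O)(=O)c2ccc(S(=O)(=O)N(CC)CC)cc2)C1`) gives 12700 nM and lies beyond the scatter from compound 1 on the stronger side. Compound 3 (`CCN(CC)S(=O)(=O)c1ccc(S(=O)(=O)N2CCC[C@@H](C(=O)N3CCN(C(=O)OC(C)(C)C)CC3)C2)cc1`) gives 200 nM and lies much further from compound 1 in the same direction.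

The open case is compound 4 (`CCOC(=O)[C@@H]1CCN(S(=O)(=O)c2ccc(S(=O)(=O)N(CC)CC)cc2)C1`). Its difference from compound 1 is the two compounds have the same atoms and bonds and differ only in configuration as drawn: 1 of 1 stereo elements differ; a stereocentre at a saturated ring carbon is drawn S in compound 1 and R in compound 4 and amounts to this: a stereocentre at a saturated ring carbon is drawn S in compound 1 and R in compound 4. For the measured compounds named here, no measured pair differs in configuration alone, so the series offers no direct size for such a step. The nearest anchor is compound 1 at 29300 nM and the expectation stays close to it, with no step beyond the scatter in this assay in either direction. The expected step is a 1.2-fold lower number from compound 1 to compound 4 (0.09 log units; within the scatter) and this estimate stays within the scatter. Compound 4 is expected at 24000 nM with an estimated range from 9000 nM to 50000 nM in this assay.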

Compound 4, half-maximal inhibitory concentration: 10000 nM
Compound 4: the middle estimate sits 2.4-fold (0.38 log units) above what was measured; measured number inside the range.
By their numbers in this assay, from the lowest: compound 3; then compounds 4 and 2 (each within the scatter of the next); then compound 1.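

Until now the series gave no size for a change of configuration alone; in this assay there is now one reading: a 2.9-fold lower number from compound 1 to compound 4 (0.47 log units; beyond the scatter). This shows that the stereocentre at a saturated ring carbon is not a neutral feature in this ester series, as the compound drawn R gives the lower number of the pair and the step lies beyond the scatter, though only modestly. The step can be assigned to configuration, and to nothing else in the structure, because the two compounds share the same atoms and bonds: the fact that compounds 1 and 4 differ only in the configuration as drawn

This remains a single pair, so it gives no indication of whether the same inversion would have a step of similar size or direction in any other compound of the series. Also open, from the compounds shown here alone, is whether the preference for the configuration drawn R persists when the ester on that ring carbon gives way to a carboxylic acid or a primary amide, since every reading for this inversion so far comes from compounds carrying the same ester.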